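Chain Against Ring in Two Hydroxycarbamoyl Inhibitors

The source may hold more compounds than are shown below. What is called first, only, known or untested is meant among the compounds shown, and "the series" means these compounds.

Compound 1 `Cn1cc(-c2ccccc2Oc2ccccc2)c2cc(C(=O)NCCCCCCC(=O)NO)[nH]c2c1=O` and compound 2 `Cn1cc(-c2ccccc2Oc2ccccc2)c2cc(C(=O)NCCCCCC(=O)NO)[nH]c2c1=O` share one core and differ only in the length of the chain that ends in the hydroxycarbamoyl group. In an assay on isolated protein for inhibition of protein deacetylase HDAC6 (Homo sapiens), read by fluorescence (a lower number here means a stronger inhibitor, a higher number a weaker inhibitor), compound 1 gives 4.7 nM, and compound 2 gives 3.4 nM. The step of a 1.4-fold lower number from compound 1 to compound 2 (0.14 log units; within the scatter) shows that the shorter chain left the number essentially unchanged. Among the measured compounds shown here, compound 2 holds the lowest of the two numbers so far, with compound 1 within the scatter of it, so neither can be called the stronger inhibitor.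

Compound 3 `Cn1cc(-c2ccccc2Oc2ccccc2)c2cc(C(=O)NCc3ccc(C(=O)NO)cc3)[nH]c2c1=O` replaces the flexible chain with a ring: 4-(hydroxycarbamoyl)phenyl in place of 4-(hydroxycarbamoyl)butyl on a saturated chain carbon bound to an amide-type nitrogen. For the measured compounds named here, only one measured step is available, and it concerns chain length rather than a chain-to-ring exchange, so it bears on the new change only loosely; it does show that the hydroxycarbamoyl group tolerates a shift in its spacing from the amide-type nitrogen. On that slim basis the expected step is a 1.5-fold higher number from compound 2 to compound 3 (0.17 log units; within the scatter), one that need not exceed the scatter. The estimate for compound 3 in this assay is 5 nM, with a range from 1.5 nM to 20 nM.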

Compound 3, half-maximal inhibitory concentration: 15.3 nM
The estimate for compound 3 lay 3.1-fold (0.49 log units) below the measured number, and the stated range covers the measured number.
By their numbers in this assay, from the lowest: compounds 2 and 1 (each within the scatter of the next); then compound 3.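

In this assay, among the compounds shown here, the exchange of chain for ring is the first change at this position to move the number beyond the scatter: 4-(hydroxycarbamoyl)phenyl in place of 4-(hydroxycarbamoyl)butyl gives a 4.5-fold higher number from compound 2 to compound 3 (0.65 log units; beyond the scatter) and, set against the longer 5-(hydroxycarbamoyl)pentyl, gives a 3.3-fold higher number from compound 1 to compound 3 (0.51 log units; beyond the scatter) in the same direction. The position that showed no readable difference between the two chains therefore does respond to what carries the hydroxycarbamoyl group, although both steps are modest and compound 3 still gives 15.3 nM on the same scale as the two chain compounds. Nothing measured here accounts for the higher number, which stands as an observation only.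

The three compounds leave open whether the ring itself or the particular spacing it imposes sets the higher number, and a phenyl ring carried on a longer saturated chain, or a saturated cyclohexyl ring in its place, would separate those two readings. They also leave open how far this holds with another group at the end of the chain, such as a carboxylic acid in place of the hydroxycarbamoyl group.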